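Swapping the amine substituent on a shared core

The source may report more compounds than this note shows. Statements on the series, on what has been measured and on what is new or still open speak of the compounds shown alone.

Measured compounds:
- Compound 1, `C=C(C)CN(CC)Cc1c(C(F)(F)F)nc2n(-c3c(C)cc(C)cc3C)c(Cl)cn12`: 67 nM
- Compound 2, `CCN(Cc1ccc(Cl)c(Cl)c1)Cc1c(C(F)(F)F)nc2n(-c3c(C)cc(C)cc3C)c(Cl)cn12`: 580 nM

In an assay on cells for displacement of a labelled ligand from corticotropin-releasing factor receptor 1 (Homo sapiens), with a stated time of 100 min (on this read-out higher numbers stand for weaker inhibition and lower numbers for stronger inhibition), compound 1 gives the lowest of the two numbers, with compound 2 the nearest at an 8.7-fold higher number from compound 1 to compound 2 (0.94 log units; beyond the scatter). Going by the values given here, that single step, 3,4-dichlorophenyl in place of 1-methylethenyl on a saturated chain carbon bound to an amine nitrogen, is the only one available for comparison.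

Compound 3, `Cc1cc(C)c(-n2c(Cl)cn3c(CN(C)Cc4ccco4)c(C(F)(F)F)nc23)c(C)c1`, is not yet measured. It differs from compound 1 by ((furan-2-yl)methyl)(methyl)amino in place of ethyl(2-methylprop-2-en-1-yl)amino on a saturated chain carbon bound to an aromatic carbon. Here, too, a non-aromatic group on the amine gives way to an aromatic ring, though a smaller one, and the ethyl is replaced by methyl, a change with no measured counterpart.

Given the weakening seen in an 8.7-fold higher number from compound 1 to compound 2 (0.94 log units; beyond the scatter), compound 3 is expected to give a moderately higher number than compound 1, a step of about a 3.0-fold higher number from compound 1 to compound 3 (0.47 log units; beyond the scatter), with an estimated value of 200 nM (range 60 nM to 700 nM) in this assay.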

Compound 3, inhibition constant: 180 nM
Estimate against measurement, compound 3: 1.1-fold (0.05 log units) above; measured number inside the range.
By their numbers in this assay, from the lowest: compound 1; then compound 3; then compound 2.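

In this assay, ((furan-2-yl)methyl)(methyl)amino in place of ethyl(2-methylprop-2-en-1-yl)amino gives a 2.7-fold higher number from compound 1 to compound 3 (0.43 log units; beyond the scatter), so this position tolerates a five-membered aromatic ring with an oxygen atom, although the number still rises. Compound 2 and compound 3 both carry an aromatic ring on the amine, and both give higher numbers than compound 1, which has no such ring. No measurement shown gives a reason for this rise.

Methyl and the furan ring enter together, so the compounds shown leave open how much of the step belongs to each, a question that the same furan-2-ylmethyl group paired with ethyl on the amine could address. Also open, as far as these compounds go, is whether a saturated tetrahydrofuran-2-ylmethyl group or a plain propyl chain would bring the number closer to that of compound 1.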